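A few compounds are considered here, and "the series" means these few. Any claim that something is new, unique, unknown or untested is made for them only; others in the source may bear on it.

Among the measured compounds shown here, compound 1 `Cc1cc(=O)n(-c2ccccc2C(F)(F)F)nc1C(=O)Nc1ccc(Oc2ncnc3ccsc23)c(F)c1` is one of two compounds measured in a functional assay on A549 cells (Homo sapiens) for cytotoxicity, read by MTT assay, with a stated time of 72 h; on this read-out lower numbers stand for stronger inhibition and higher numbers for weaker inhibition. In this assay compound 1 gives 4680 nM, the highest of the two numbers, and the nearest is compound 2 `Cc1cc(=O)n(-c2ccc(F)c(F)c2)nc1C(=O)Nc1ccc(Oc2ncnc3ccsc23)c(F)c1`, which gives 4590 nM. For the measured compounds named here, the only step between measured compounds, a 1.0-fold lower number from compound 1 to compound 2 (0.01 log units; within the scatter), exchanges the group on the aromatic nitrogen and leaves everything else in the shared core untouched.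

Compound 3 `Cc1cc(=O)n(-c2ccccc2C(F)(F)F)nc1C(=O)Nc1ccc(Oc2ncnc3sccc23)c(F)c1` has the same atoms as compound 1, joined differently: a group of 9 heavy atoms (6 carbon, 2 nitrogen, 1 sulfur; one five-membered aromatic ring with 1 hetero atom, one six-membered aromatic ring with 2 hetero atoms) in place of a group of 9 heavy atoms (6 carbon, 2 nitrogen, 1 sulfur; one five-membered aromatic ring with 1 hetero atom, one six-membered aromatic ring with 2 hetero atoms), on an oxygen on an aromatic ring. Going by the values given here, this change lies on the oxygen and not on the aromatic nitrogen, so no measured step bears on it directly; the single step on hand shows only that the group on the aromatic nitrogen can be swapped without a change beyond the scatter. With nothing in the measured compounds to show that rejoining the group on the oxygen shifts the number, the expected step in this assay is none beyond the scatter, in no particular direction, although the uncertainty is wider than for a change with a measured precedent.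

Compound 3 is therefore estimated at 4700 nM, with a range from 2000 nM to 11000 nM, which corresponds to an expected step of a 1.0-fold higher number from compound 1 to compound 3 (0.00 log units; within the scatter).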

Compound 3, half-maximal inhibitory concentration: 16300 nM
Compound 3: the middle estimate sits 3.5-fold (0.54 log units) below what was measured, outside the stated range (above it).
By their numbers in this assay, from the lowest: compounds 2 and 1 (each within the scatter of the next); then compound 3.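

In this assay, rejoining the group on the oxygen on an aromatic ring gives a 3.5-fold higher number from compound 1 to compound 3 (0.54 log units; beyond the scatter), so this position responds to how the group is joined, even though the atoms stay the same and the counts of heavy atoms, hydrogen-bond donors, hydrogen-bond acceptors and rings do not differ between the leaving and entering groups. The earlier step on the aromatic nitrogen, a 1.0-fold lower number from compound 1 to compound 2 (0.01 log units; within the scatter), had shown no change beyond the scatter, so this is the first change among the compounds shown that moves the number, and it moves it towards weaker inhibition. Nothing available here accounts for this difference between the two joinings.

The compounds shown leave open whether the same rejoining would move the number by a similar amount with 3,4-difluorophenyl on the aromatic nitrogen in place of 2-(trifluoromethyl)phenyl, as that pairing is not among them. They also leave open how the number would respond to a further change in the group on the oxygen, such as a methoxy group or a morpholine attached to it, since a single rejoining is all that speaks for this position.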